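Replacing (dimethylamino)methyl with pyridin-4-yl on a carbonyl carbon

A few compounds are considered here, and "the series" means these few. Any claim that something is new, unique, unknown or untested is made for them only; others in the source may bear on it.

In a physicochemical assay for solubility (on this read-out higher numbers stand for higher solubility and lower numbers for lower solubility), compound 1 (`CC(=O)N1CCC[C@H]1C(=O)N1CCC(NS(=O)(=O)c2cc(S(=O)(=O)c3ccccc3)ccc2C(F)(F)F)CC1`) gives 12500 nM and compound 2 (`CC(C)(C)CC(=O)N1CCC[C@H]1C(=O)N1CCC(NS(=O)(=O)c2cc(S(=O)(=O)c3ccccc3)ccc2C(F)(F)F)CC1`) gives 25000 nM while compound 3 (`CN(C)CC(=O)N1CCC[C@H]1C(=O)N1CCC(NS(=O)(=O)c2cc(S(=O)(=O)c3ccccc3)ccc2C(F)(F)F)CC1`) gives 100000 nM as the highest number of the three. Both steps to compound 3 lie beyond the scatter: an 8.0-fold higher number from compound 1 to compound 3 (0.90 log units; beyond the scatter) and a 4.0-fold higher number from compound 2 to compound 3 (0.60 log units; beyond the scatter) are modest, whereas a 2.0-fold higher number from compound 1 to compound 2 (0.30 log units; within the scatter) stays within it. Compound 4 (`O=C([C@@H]1CCCN1C(=O)c1ccncc1)N1CCC(NS(=O)(=O)c2cc(S(=O)(=O)c3ccccc3)ccc2C(F)(F)F)CC1`) carries pyridin-4-yl in place of (dimethylamino)methyl on a carbonyl carbon. Among the compounds with values here, no measured step introduces pyridin-4-yl, so only the steps into compound 3 bear on it, and a modest fall in this assay is expected, of about the size of a 4.0-fold higher number from compound 2 to compound 3 (0.60 log units; beyond the scatter) in reverse. The estimate therefore means a lower number (a 3.3-fold lower number from compound 3 to compound 4 (0.52 log units; beyond the scatter)). Compound 4 is expected at 30000 nM with an estimated range of 10000 nM to 90000 nM in this read-out.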

Compound 4, solubility: 100000 nM
Compound 4: middle estimate off by 3.3-fold (0.52 log units), on the low side; measured number outside the range, above it.
By their numbers in this assay, from the lowest: compounds 1 and 2 (each within the scatter of the next); then compounds 3 and 4 (each within the scatter of the next).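

In this assay, pyridin-4-yl on this carbonyl carbon does as well as (dimethylamino)methyl, with no change at the digits printed from compound 3 to compound 4 (within the scatter), so a six-membered aromatic ring with one hetero atom serves here as well as the open chain. Pyridin-4-yl also stands clear of neopentyl and methyl, with a 4.0-fold higher number from compound 2 to compound 4 (0.60 log units; beyond the scatter) and an 8.0-fold higher number from compound 1 to compound 4 (0.90 log units; beyond the scatter). Nothing available accounts for this result.

As far as these compounds go, it remains open whether phenyl or pyridin-3-yl on the same carbonyl carbon would match compound 4. A longer chain ending in an amine, or a carboxylic acid, is equally untested in what is shown here.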